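Benzyl Substituent Variation in a Bis(trifluoromethyl)sulfonamide Series

This account rests on a few compounds, and the source may have more. Where it says the series, first, only, none or still open, it means among the compounds named here.

Measured in a functional assay on HPAC cells (Homo sapiens) for inhibition, read by MTT assay, with a stated time of 72 h; on this read-out lower numbers stand for stronger inhibition of growth and higher numbers for weaker inhibition of growth:
compound 1, `O=S(=O)(NCCCNCc1ccccc1Cl)c1cc(C(F)(F)F)cc(C(F)(F)F)c1`, gives 10000 nM
compound 2, `O=S(=O)(NCCCNCc1ccc(C(F)(F)F)cc1)c1cc(C(F)(F)F)cc(C(F)(F)F)c1`, gives 2700 nM

Compound 2 stands lowest of these two numbers; its nearest neighbour is compound 1, and the change a 3.7-fold lower number from compound 1 to compound 2 (0.57 log units; beyond the scatter) lies beyond the scatter. Compound 3, `O=S(=O)(NCCCNCc1ccccc1)c1cc(C(F)(F)F)cc(C(F)(F)F)c1`, differs from compound 2 by hydrogen in place of trifluoromethyl on an aromatic carbon. For the measured compounds named here, only that one step bears on this change, and it swaps whole substituents rather than removing one alone, so it guides loosely. The expected step is a 2.2-fold higher number from compound 2 to compound 3 (0.35 log units; beyond the scatter), a modest weakening. For compound 3 the estimate is 6000 nM, expected between 2500 nM and 15000 nM.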

Compound 3, concentration for 50% growth inhibition: 3200 nM
Beside the measured number, compound 3's estimate is 1.9-fold (0.27 log units) above it; low and high end bracket the measured number.
By their numbers in this assay, from the lowest: compounds 2 and 3 (each within the scatter of the next); then compound 1.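

In this assay, the trifluoromethyl of compound 2 proves dispensable at this position, since its replacement by hydrogen leaves the number within the scatter (a 1.2-fold higher number from compound 2 to compound 3 (0.07 log units; within the scatter)). The plain benzyl also separates from the chlorinated compound (a 3.1-fold lower number from compound 1 to compound 3 (0.49 log units; beyond the scatter)), so it is the 2-chlorophenyl of compound 1 that stands apart, not the 4-(trifluoromethyl)phenyl of compound 2. The compounds shown leave open how a methoxy, a nitrile or a chloro would behave where the trifluoromethyl stood, and how a longer chain would change the numbers. No measurement here explains either step.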